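A few compounds are considered here, and "the series" means these few. Any claim that something is new, unique, unknown or untested is made for them only; others in the source may bear on it.

Of the compounds shown here, three have so far been tested in a functional assay on HCT-116 cells (Homo sapiens) for inhibition, read by MTT assay, with a stated time of 72 h; a higher number here means a weaker inhibitor of growth, a lower number a stronger inhibitor of growth. Compound 1 `CNC(=O)/C=C/c1ccncc1-c1ccc2cc[nH]c2c1` gives 10400 nM in this assay, and compound 2 `Cn1ccc2cc(-c3cnccc3/C=C/C(=O)O)ccc21` gives 7260 nM; these two numbers lie within the usual scatter of each other. Compound 3 `O=C(O)/C=C/c1ccncc1-c1ccc2cc[nH]c2c1` reaches only the limit > 30000 nM in this assay, so no number is known for it. On these data alone, compound 1 differs from compound 3 by methylamino in place of hydroxy on a carbonyl carbon; this change brought an at least 2.8-fold lower number from compound 3 to compound 1 (0.46 log units; beyond the scatter), a step whose true size stays open because of the limit of > 30000 nM in this assay, at which 1 of the 3 values shown sits. Compound 4 `CNC(=O)/C=C/c1ccncc1-c1ccc2c(ccn2C)c1` is not yet measured. It differs from compound 2 by methylamino in place of hydroxy on a carbonyl carbon, the same change at the same place. The difference between the cores of compound 2 and compound 3 is not broken down here. Given an at least 2.8-fold lower number from compound 3 to compound 1 (0.46 log units; beyond the scatter), compound 4 is expected to show a 2.4-fold lower number from compound 2 to compound 4 (0.38 log units; beyond the scatter). Compound 4 is therefore estimated at 3000 nM, likely between 1000 nM and 10000 nM.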

Compound 4, concentration for 50% growth inhibition: 4450 nM
Compound 4: middle estimate off by 1.5-fold (0.17 log units), on the low side; low and high end bracket the measured number.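

In this assay, putting methylamino in place of hydroxy on the carbonyl carbon brought a 1.6-fold lower number from compound 2 to compound 4 (0.21 log units; within the scatter), so on this core the change cannot be told apart from the variation between repeated measurements. Set beside the same change on the other core, the result shows neither that the step carries over at the same size nor that it shrinks: the same change on two cores in this assay, an at least 2.8-fold lower number (0.46 log units; beyond the scatter) from compound 3 to compound 1 and a 1.6-fold lower number (0.21 log units; within the scatter) from compound 2 to compound 4; the limit leaves it open whether they differ. On these data alone, compound 3 gives only a limit, so the size of the earlier step remains unknown: the limit of > 30000 nM in this assay, at which 1 of the 4 values shown sits.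

Still open, as far as these compounds go, is how an unsubstituted amino group or a longer chain, such as ethylamino, in place of methylamino would behave on these two cores. From the compounds shown here alone, a dimethylamino group, which has no amide hydrogen, is equally open.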